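The source may hold more compounds than are shown below. What is called first, only, known or untested is meant among the compounds shown, and "the series" means these compounds.

In a functional assay on HCT-116 cells (Homo sapiens), read by MTT assay, with a stated time of 72 h (a higher number here means a weaker inhibitor, a lower number a stronger inhibitor), compound 1 `Cc1nc(N)c2c(-c3ccccc3)cn([C@@H]3O[C@H](CO)[C@@H](O)[C@H]3O)c2n1` gives > 100000 nM, which is a limit and not a number. Compound 2 `C#Cc1cn([C@@H]2O[C@H](CO)[C@@H](O)[C@H]2O)c2nc(C)nc(N)c12` gives > 20000 nM in this assay, and this is also a limit. Compound 2 therefore has no exact position on the scale, and the only other result available offers no exact number to compare it with.

Compound 3 `Cc1nc(N)c2c(I)cn([C@@H]3O[C@H](CO)[C@@H](O)[C@H]3O)c2n1` keeps the shared core but replaces one group: iodo in place of ethynyl on an aromatic carbon. Here, iodo takes the place of ethynyl on an aromatic carbon of a five-membered aromatic ring.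

Among the compounds with values here, the one measured step that bears on this change is a step that the two limits leave unreadable from compound 1 to compound 2. It alters the same carbon, but it provides no size to carry over, so any forecast must remain broad. Since compound 2 reaches only the limit of > 20000 nM, compound 3 is expected to remain a weak inhibitor in this assay, with no firm direction of change. The expected result is a step that the limit leaves unreadable from compound 2 to compound 3. For compound 3, the estimated value is 30000 nM, with an expected range from 5000 nM to 100000 nM.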

Compound 3, half-maximal inhibitory concentration: > 20000 nM
Compound 3: a limit, no number; the forecaster's own chance of this, stated with the estimate: 75%; the middle value lies beyond the limit too.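

Compound 3 gives > 20000 nM in this assay, which is a limit and not a number. Within the data shown here, with only limits for compound 1, compound 2 and compound 3, no step among them can be read. On these data alone, what stays open is how strongly each of the three inhibits, and whether phenyl, ethynyl or iodo on that aromatic carbon makes any difference.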